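Small expected shift on swapping ethyl for trifluoromethyl

The source may hold more compounds than are shown below. What is called first, only, known or untested is meant among the compounds shown, and "the series" means these compounds.

Compound 1 `O=C1C(Nc2ccc(I)cc2)=CC(=O)c2c1nc1n2[C@H]2OC[C@@H](O)[C@H]2OC1` gives 2150 nM
Compound 2 `O=C1C=C(N2CCC2)C(=O)c2c1nc1n2[C@H]2OC[C@@H](O)[C@H]2OC1` gives > 16000 nM as a limit of the assay, not a number
Compound 3 `CCc1ccc(NC2=CC(=O)c3nc4n(c3C2=O)[C@H]2OC[C@@H](O)[C@H]2OC4)cc1` gives 1290 nM

All three entries come from a functional assay on MGC-803 cells (Homo sapiens) for inhibition, read by sulforhodamine B assay (a lower number here means a stronger inhibitor, a higher number a weaker inhibitor), and share one core. Compound 3 at 1290 nM and compound 1 at 2150 nM lie within the scatter of each other, so neither ranks ahead of the other.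

Compound 4 `O=C1C=C(Nc2ccc(C(F)(F)F)cc2)C(=O)c2c1nc1n2[C@H]2OC[C@@H](O)[C@H]2OC1` keeps the core of compound 3 and differs in one place: trifluoromethyl in place of ethyl on an aromatic carbon (trifluoromethyl in place of ethyl on an aromatic carbon, para to a large group). Among the measured compounds shown here, the only measured step that reaches compound 3 is an at least 12-fold lower number from compound 2 to compound 3 (1.09 log units; beyond the scatter) and it is large, beyond the scatter. For the measured compounds named here, that step exchanges azetidin-1-yl for the whole (4-ethylphenyl)amino group, however, and no measured step changes the ethyl alone. It therefore gives no direct size for this swap, which leaves the phenylamino attachment in place. The expectation rests instead on compound 3 at 1290 nM as the starting point. Only a small move towards a slightly higher number is expected, a 1.2-fold higher number from compound 3 to compound 4 (0.09 log units; within the scatter) and so nothing beyond the scatter. Compound 4 is expected at 1600 nM with an estimated range of 650 nM to 4000 nM in this assay for this compound.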

Compound 4, half-maximal inhibitory concentration: 2820 nM
For compound 4 the middle estimate is 1.8-fold (0.25 log units) below the measured one, within the range that was stated.
By their numbers in this assay, from the lowest: compounds 3, 1 and 4 (each within the scatter of the next, the first and the last beyond it). At a limit, above all of these: compound 2.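

In this assay, changing the ethyl alone while the phenylamino attachment stays in place gives a 2.2-fold higher number from compound 3 to compound 4 (0.34 log units; beyond the scatter) and so lies beyond the usual scatter, which shows that the group on this aromatic carbon affects the read-out by itself. The earlier step, an at least 12-fold lower number from compound 2 to compound 3 (1.09 log units; beyond the scatter), could not show this, as it exchanged the whole azetidin-1-yl group for the (4-ethylphenyl)amino group and so gave no separate measure of the end of that substituent. The new step is modest beside that one and, for this single pair, ethyl gives the lower number, but the data shown offer no explanation for the difference.

Going by these compounds, one pair at this position sets no trend, so it remains open how far the number would move with a methoxy group, an amine or a carboxylic acid in the same place. On these data alone, it also remains open whether a longer chain than ethyl would lower the number further or raise it.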